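Tolyl for methoxyphenyl on the triazole of compound 1

A few compounds are considered here, and "the series" means these few. Any claim that something is new, unique, unknown or untested is made for them only; others in the source may bear on it.

The series is followed in a functional assay on HepG2 cells (Homo sapiens) for antiproliferative activity, read by MTT assay, with a stated time of 72 h; a higher number here means a weaker inhibitor, a lower number a stronger inhibitor. Compound 1 `COc1ccccc1-c1cn(C[C@H](O)[C@H]2OC(=O)C(OCc3ccccc3)=C2OCc2ccccc2)nn1` is the reference point; in this assay compound 1 gives > 100000 nM, which is a limit of the assay and not a number. Compound 2 `O=C1O/C(=C\Cn2cc(-c3cc(C(F)(F)F)cc(C(F)(F)F)c3)nn2)C(OCc2ccccc2)=C1OCc1ccccc1` in this assay also sits at a limit, > 100000 nM. Compound 3 `COc1ccc(-c2cn(C/C=C3\OC(=O)C(OCc4ccccc4)=C3OCc3ccccc3)nn2)cc1` in this assay likewise returns a limit, > 100000 nM. On the numbers shown, compound 1 therefore stands only at a limit, and the two further values are limits as well; every value in hand sits at the limit of > 100000 nM in this assay, at which 3 of the 3 values shown sit, so no ordering among compound 1, compound 2 and compound 3 can be read from them.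

Compound 4 `Cc1ccc(-c2cn(C[C@H](O)[C@H]3OC(=O)C(OCc4ccccc4)=C3OCc3ccccc3)nn2)cc1` has not yet been measured in this assay. It differs from compound 1 by 4-methylphenyl in place of 2-methoxyphenyl on an aromatic carbon. Within the data shown here, no step between measured compounds is available to calibrate this change. Given that compound 1, compound 2 and compound 3 all sit at the limit of > 100000 nM in this assay, at which 3 of the 3 values shown sit, the expected step from compound 1 to compound 4 is a step that the limit leaves unreadable from compound 1 to compound 4, that is none beyond the scatter. The estimate for compound 4 in this assay is 150000 nM, with a range from 40000 nM to 500000 nM, and the likeliest outcome is again a limit rather than a number.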

Compound 4, half-maximal inhibitory concentration: 8770 nM
Beside the measured number, compound 4's estimate is 17-fold (1.23 log units) above it, and the stated range ends above it.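

In this assay, the aryl group on an aromatic carbon of the five-membered aromatic ring with 3 nitrogen proves able to move a compound off the limit: 4-methylphenyl in place of 2-methoxyphenyl gives an at least 11-fold lower number from compound 1 to compound 4 (1.05 log units; beyond the scatter). Compound 1 gives > 100000 nM, which is a limit of the assay and not a number. The step is therefore a lower bound on the size of the change, not its full size, and compound 4 is the only compound in this set with a readable value: the limit of > 100000 nM in this assay, at which 3 of the 4 values shown sit.

The change replaces a methoxy group with a methyl group and also alters where the substituent sits on the phenyl ring, so the compounds shown do not tell which of the two carries the step. Also open, from the compounds shown here alone, is how the shared core of compound 4 responds to an unsubstituted phenyl, or to an amine or a carboxylic acid on that phenyl ring, and whether any such group would give a lower number in this assay than compound 4 does.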